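Furan to pyridine on the shared core of compound 2

This account rests on a few compounds, and the source may have more. Where it says the series, first, only, none or still open, it means among the compounds named here.

Compound 1 `Oc1cccc(-c2cc(-c3cccs3)cc(-c3cccc(O)c3)n2)c1` and compound 2 `Oc1cccc(-c2cc(-c3ccco3)cc(-c3cccc(O)c3)n2)c1` were both tested in an assay on isolated protein for inhibition of DNA topoisomerase 1 (Homo sapiens), with a stated time of 30 min, tested at 100 uM (a lower number here means a weaker effect, a higher number a stronger effect of the compound at the concentration tested), where compound 1 gives 91.7% and compound 2 gives 97.8%. Among the measured compounds shown here, the only step recorded, a number 6.1 percentage points higher from compound 1 to compound 2 (within the scatter), leaves compound 2 with the higher of the two numbers, but not beyond the scatter. Compound 3 `Oc1cccc(-c2cc(-c3cccnc3)cc(-c3cccc(O)c3)n2)c1` differs from compound 2 by pyridin-3-yl in place of furan-2-yl on an aromatic carbon. For the measured compounds named here, no measured step covers a pyridin-3-yl, so only the flat furan-to-thiophene comparison bears on it, and no step beyond the scatter is expected in this assay. Compound 3 is therefore expected to give 90%, within 72% to 99%, meaning an estimated a number 7.8 percentage points lower from compound 2 to compound 3 (within the scatter).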

Compound 3, a percentage reported as inhibition, at one concentration (the size of the read-out at that concentration, not a potency): 2.1%
For compound 3 the middle estimate is 87.9 percentage points above the measured one; measured number outside the range, below it.
By their numbers in this assay, from the lowest: compound 3; then compounds 1 and 2 (each within the scatter of the next).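

In this assay pyridin-3-yl in place of furan-2-yl gives a number 95.7 percentage points lower from compound 2 to compound 3 (beyond the scatter) and pyridin-3-yl in place of thiophen-2-yl gives a number 89.6 percentage points lower from compound 1 to compound 3 (beyond the scatter). The position opposite the ring nitrogen therefore does not accept every aromatic ring with 1 hetero atom, although furan-2-yl and thiophen-2-yl could not be told apart there. No measurement available here accounts for this loss. From the compounds shown here alone, it remains open whether the loss follows the six-membered ring or its nitrogen, which phenyl would help separate. Pyridin-2-yl and pyridin-4-yl would show whether the place of that nitrogen matters.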